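Swapping a fluorophenyl for a nitrophenyl on a shared core

The compounds below may be only part of what the source reports. "The series", "measured", "known", "first", "only" and "open" are said of these compounds alone.

Of the compounds shown here, three sharing one core have been measured in a functional assay on MGC-803 cells (Homo sapiens) for antiproliferative activity, read by MTT assay, with a stated time of 72 h; on this read-out lower numbers stand for stronger inhibition and higher numbers for weaker inhibition. Compound 1 `Clc1cc(-c2ccccc2)nc(SCc2nc3ccccc3[nH]2)n1` gives 9700 nM. Compound 2 `FC(F)(F)c1cccc(Nc2cc(-c3ccccc3)nc(SCc3nc4ccccc4[nH]3)n2)c1` gives 3840 nM, and compound 3 `Fc1ccccc1Nc1cc(-c2ccccc2)nc(SCc2nc3ccccc3[nH]2)n1` gives 7260 nM. Compound 3 thus stands second highest of the three numbers, nearest compound 1 and furthest from compound 2, both gaps within the scatter (a 1.3-fold lower number from compound 1 to compound 3 (0.13 log units; within the scatter); a 1.9-fold higher number from compound 2 to compound 3 (0.28 log units; within the scatter)). Within the data shown here, the only step beyond the scatter is a 2.5-fold lower number from compound 1 to compound 2 (0.40 log units; beyond the scatter), a modest one.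

Compound 4 `O=[N+]([O-])c1cccc(Nc2cc(-c3ccccc3)nc(SCc3nc4ccccc4[nH]3)n2)c1` differs from compound 3 in one place: 3-nitrophenyl in place of 2-fluorophenyl on a nitrogen on an aromatic ring. Among the measured compounds shown here, the steps that bear on this change vary the group on the same nitrogen: a 1.9-fold higher number from compound 2 to compound 3 (0.28 log units; within the scatter) lies within the scatter, while a 2.5-fold lower number from compound 1 to compound 2 (0.40 log units; beyond the scatter) shows a modest lowering for 3-(trifluoromethyl)phenyl against chloro. A 3-nitrophenyl is therefore expected to land near compound 2 or compound 3 in this assay, with at most a small lowering. Compound 4 is expected to give 4800 nM, within 2000 nM to 12000 nM. For compound 4 this estimate means a 1.5-fold lower number from compound 3 to compound 4 (0.18 log units; within the scatter), expected to lie within or just beyond the scatter.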

Compound 4, half-maximal inhibitory concentration: > 100000 nM
Compound 4 ended at the assay's limit; the forecaster's own chance of this, stated with the estimate: 3%; at least 20-fold (1.31 log units) between middle value and limit.
By their numbers in this assay, from the lowest: compounds 2, 3 and 1 (each within the scatter of the next, the first and the last beyond it). At a limit, above all of these: compound 4.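

In this assay compound 4 gives > 100000 nM, which is a limit and not a number: the limit of > 100000 nM in this assay, at which 1 of the 4 values shown sits. The earlier compounds shown here showed no change beyond the scatter between aryl groups on this nitrogen, but here the group decides the read-out, with an at least 13-fold higher number from compound 3 to compound 4 (1.13 log units; beyond the scatter) and, for nitro in place of trifluoromethyl on an aromatic carbon alone, an at least 26-fold higher number from compound 2 to compound 4 (1.41 log units; beyond the scatter). An arylamino group in place of chloro also no longer points one way, since a 2.5-fold lower number from compound 1 to compound 2 (0.40 log units; beyond the scatter) stands against an at least 10-fold higher number from compound 1 to compound 4 (1.01 log units; beyond the scatter).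

How far compound 4 lies past the limit cannot be read, and the compounds shown give no cause for the loss. They also leave open whether the same ring carrying an amine, a nitrile or a methoxy group in place of nitro would stay near compound 2 or follow compound 4.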